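This account rests on a few compounds, and the source may have more. Where it says the series, first, only, none or still open, it means among the compounds named here.

Compound 1 `COc1cc(C(=O)N2CCCC2)ccc1-c1ccnc2[nH]c(C3CCOCC3)cc12` gives 15 uL/min in an ADME assay on cells (Hepatocyte, Rattus norvegicus) for metabolic stability; on this read-out higher numbers stand for fast clearance and lower numbers for slow clearance. Compound 2 `CN(C)C(=O)CN1CCC(c2cc3c(-c4ccc(=O)n(C)c4)ccnc3[nH]2)CC1` gives < 1 uL/min in this assay. Compound 3 `COc1cc(F)ccc1-c1ccnc2[nH]c(C3CCOCC3)cc12` gives 97 uL/min in this assay.

Compound 2 stands at the limit of < 1 uL/min in this assay, at which 1 of the 3 values shown sits, so its value is a limit of the assay rather than a number, and on the numbers shown it sits at the slow-clearance end. Compound 4 `CCn1cc(-c2ccnc3[nH]c(C4CCN(CC(=O)N(C)C)CC4)cc23)ccc1=O` differs from compound 2 by methyl in place of hydrogen on a saturated chain carbon bound to an aromatic nitrogen. Among the measured compounds shown here, the single measured step, a 6.5-fold higher number from compound 1 to compound 3 (0.81 log units; beyond the scatter), concerns a different change on an aromatic carbon and does not bear on this one. For the measured compounds named here, with compound 2 at the limit of < 1 uL/min in this assay, at which 1 of the 3 values shown sits, and no relevant step, the change from compound 2 to compound 4 is expected to give an at least 1.2-fold higher number from compound 2 to compound 4 (0.07 log units; that floor lies within the scatter), nothing beyond the scatter. Compound 4 is therefore estimated at 1.2 uL/min, between 0.5 uL/min and 3 uL/min, possibly again only a limit.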

Compound 4, intrinsic clearance in a liver preparation (reported as CLH), per the amount of preparation that the assay uses: < 1 uL/min
Compound 4 gave a limit, no number; the forecaster's own chance of this, stated with the estimate: 50%; at least 1.2-fold (0.07 log units) between middle value and limit.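

Among the compounds shown here, compound 2 and compound 4 both give a limit rather than a number, so no step between them can be read: the limit of < 1 uL/min in this assay, at which 2 of the 4 values shown sit. The compounds shown leave open whether the change from methyl to ethyl alters clearance at all.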